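The compounds below may be only part of what the source reports. "The series", "measured", "known", "first", "only" and "open" are said of these compounds alone.

In a physicochemical assay for lipophilicity, measured as octanol-water partition, at pH 7.4 (on this read-out higher numbers stand for higher lipophilicity and lower numbers for lower lipophilicity), compound 3 `O=S(=O)(O)Nc1ccc(-c2nc3ccccc3s2)cc1` gives 3.4, the lower of the two numbers in the series. Compound 1 `Cc1cc(-c2nc3ccccc3s2)ccc1N` gives 3.96. The gap between these two numbers lies beyond the scatter. Compound 2 `Nc1ccc(-c2nc3ccccc3s2)cc1Br` reports only a limit, > 3.3. Compound 4 `O=S(=O)(O)Nc1ccc(-c2nc3ccccc3s2)cc1I` carries iodo in place of hydrogen on an aromatic carbon, ortho to a sulfoamino group: iodo in place of hydrogen on an aromatic carbon. Among the measured compounds shown here, the only measured step bearing on this change is a step that the limit leaves unreadable from compound 1 to compound 2, and it offers no size to carry over because of the limit of > 3.3 in this assay, at which 1 of the 3 values shown sits. The expectation therefore rests on the structural change alone, and an upward move beyond the scatter is expected in this assay, estimated as a number 0.50 log units higher from compound 3 to compound 4 (beyond the scatter). For compound 4 the estimated value is 3.9, with an expected range of 3.4 to 4.5.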

Compound 4, distribution coefficient: 1.8
The estimate for compound 4 lay 2.10 log units above the measured number, outside the stated range (below it).
By their numbers in this assay, from the lowest: compound 4; then compound 3; then compound 1.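

In this assay, iodo in place of hydrogen on an aromatic carbon, ortho to a sulfoamino group, gives a number 1.60 log units lower from compound 3 to compound 4 (beyond the scatter). This is the only readable size for a change at this position in the series, and its direction is downward. The step with bromo in place of methyl, from compound 1 to compound 2, cannot be read: the limit of > 3.3 in this assay, at which 1 of the 4 values shown sits.

As far as these compounds go, whether the same downward step holds with chloro at this position, or with a carboxylic acid in place of the sulfoamino group, stays open.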